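Working notes: compound 3 to compound 4

A few compounds are considered here, and "the series" means these few. Any claim that something is new, unique, unknown or untested is made for them only; others in the source may bear on it.

Three compounds share one core and differ only in the aromatic group attached at one aromatic carbon. Compound 1 `Cc1cc(-c2ccc(C#N)cc2)cc(C)c1Nc1ccnc(Nc2ccc(C#N)cc2)n1` gives 2080 nM in an ADME assay on MT4 cells (Homo sapiens) for cytotoxicity, read by MTT assay, with a stated time of 4 days; a higher number here means that more compound is tolerated, a lower number that less compound is tolerated. Compound 2 `Cc1cc(-c2cccc(C(F)(F)F)c2)cc(C)c1Nc1ccnc(Nc2ccc(C#N)cc2)n1` gives 4030 nM in this assay, and compound 3 `Cc1cc(-c2ccccc2F)cc(C)c1Nc1ccnc(Nc2ccc(C#N)cc2)n1` gives 2120 nM in this assay. The three numbers sit close together: a 1.9-fold higher number from compound 1 to compound 2 (0.29 log units; within the scatter), a 1.0-fold higher number from compound 1 to compound 3 (0.01 log units; within the scatter) and a 1.9-fold lower number from compound 2 to compound 3 (0.28 log units; within the scatter). Compound 3 thus holds the second highest of the three numbers, with compound 1 nearest and compound 2 furthest, neither separation beyond the scatter.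

Compound 4 `Cc1cccc(-c2cc(C)c(Nc3ccnc(Nc4ccc(C#N)cc4)n3)c(C)c2)c1` is still to be measured. The change is 3-methylphenyl in place of 2-fluorophenyl on an aromatic carbon. All three measured steps bear on it, since each also swaps one aromatic group at this same aromatic carbon, and none of them left the scatter. No step beyond the scatter is therefore expected in this assay for this swap; the step expected from compound 3 to compound 4 is a 1.2-fold higher number from compound 3 to compound 4 (0.09 log units; within the scatter). For compound 4 the estimate is 2600 nM, with an expected range from 1200 nM to 5500 nM.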

Compound 4, half-maximal cytotoxic concentration: 3670 nM
Estimate against measurement, compound 4: 1.4-fold (0.15 log units) below; the measured number falls inside the stated range.
By their numbers in this assay, from the lowest: compounds 1, 3, 4 and 2 (each within the scatter of the next).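

In this assay a fourth aromatic group on this aromatic carbon, 3-methylphenyl, stays within the scatter of the other three: the readings are a 1.7-fold higher number from compound 3 to compound 4 (0.24 log units; within the scatter) and a 1.8-fold higher number from compound 1 to compound 4 (0.25 log units; within the scatter) as well as a 1.1-fold lower number from compound 2 to compound 4 (0.04 log units; within the scatter) in a change confined to methyl in place of trifluoromethyl on an aromatic carbon. Across compounds 1 to 4, this position therefore tolerates all four aromatic groups shown without any step leaving the scatter, including a group that carries only carbon atoms. Nothing measured here explains the small differences that remain.

Going by these compounds, whether the scatter would still hold with an amine or a carboxylic acid on the aromatic ring stays open. A longer alkyl chain in place of the aromatic ring on this carbon is equally untested by the compounds shown.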